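Swapping methoxy for diethylamino among limits

This account rests on a few compounds, and the source may have more. Where it says the series, first, only, none or still open, it means among the compounds named here.

Measured in an ADME assay on HepG2 cells (Homo sapiens) for cytotoxicity, read by MTT assay, with a stated time of 72 h; a lower number here means that less compound is tolerated, a higher number that more compound is tolerated:
- Compound 1 `O=[N+]([O-])c1c(CS(=O)(=O)c2ccccc2)nc2c(-c3ccccc3)cc(Cl)cn12`: > 15600 nM (a limit)
- Compound 2 `O=[N+]([O-])c1c(CS(=O)(=O)c2ccccc2)nc2c(-c3ccc(Cl)cc3)cc(Cl)cn12`: > 3900 nM (a limit)
- Compound 3 `COc1ccc(-c2cc(Cl)cn3c([N+](=O)[O-])c(CS(=O)(=O)c4ccccc4)nc23)cc1`: > 3900 nM (a limit)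

Compound 3 therefore has no exact number, only a limit, and so do the other two. The closest reference point is the limit of > 3900 nM in this assay, at which 2 of the 3 values shown sit.

Compound 4 `CCN(CC)c1ccc(-c2cc(Cl)cn3c([N+](=O)[O-])c(CS(=O)(=O)c4ccccc4)nc23)cc1` carries diethylamino in place of methoxy on an aromatic carbon, para to a large group: diethylamino in place of methoxy on an aromatic carbon.

The measured changes at this carbon are a step that the two limits leave unreadable from compound 1 to compound 3 and a step that the two limits leave unreadable from compound 2 to compound 3, and a step that the two limits leave unreadable from compound 1 to compound 2 is the third. None has a readable size, so they point to no direction, and no shift beyond the scatter is expected in this assay. The expected change is a step that the limit leaves unreadable from compound 3 to compound 4. Compound 4 is estimated at 5000 nM, with an expected range of 1800 nM to 16000 nM.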

Compound 4, half-maximal cytotoxic concentration: > 15600 nM
Compound 4 gave a limit, no number; the forecaster's own chance of this, stated with the estimate: 70%; middle value at least 3.1-fold (0.49 log units) from the limit.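

Compound 4, like compound 1, compound 2 and compound 3, gives only a limit, so none of the steps to compound 4 can be read. The compounds shown leave open whether diethylamino, methoxy, chloro or hydrogen at this carbon makes any difference to the concentration tolerated.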